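The source may hold more compounds than are shown below. What is called first, only, known or untested is meant among the compounds shown, and "the series" means these compounds.

Compound 1 `COc1ccc(C2OC(c3cc(OC)c(OC)c(OC)c3)=NN2C(C)=O)cc1OC(C)=O`: 3900 nM
Compound 2 `COc1ccccc1C1OC(c2cc(OC)c(OC)c(OC)c2)=NN1C(C)=O`: 48000 nM
Compound 3 `COc1cc(C2=NN(C(C)=O)C(c3cc(OC)c(OC)c(OC)c3)O2)cc(OC)c1OC`: > 100000 nM (a limit, not a number)

All three compounds were tested in a functional assay on L1210 cells (Mus musculus) for antiproliferative activity, read by MTT assay, with a stated time of 72 h; a lower number here means a stronger inhibitor, a higher number a weaker inhibitor. Of the two compounds with a numerical result, compound 2 has the higher value, at 48000 nM. It is therefore the weaker inhibitor of the pair, and its gap to compound 1 lies beyond the usual scatter. Compound 3 gives only a limit, so it cannot be placed exactly against the others.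

The account now turns to compound 4 `COc1cc(C2=NN(C(C)=O)C(c3cccc(Br)c3)O2)cc(OC)c1OC`, which has not yet been measured. Relative to compound 2, it has 3-bromophenyl in place of 2-methoxyphenyl on a saturated ring carbon. Going by the values given here, no two measured compounds differ in only one place, so the size of this step cannot be read directly from the data. Compound 1, at 3900 nM, shows that a compound in this set can reach a much lower number than compound 2. A moderate move toward stronger inhibition in this assay is therefore expected, only slightly beyond the scatter. The estimated change is a 2.4-fold lower number from compound 2 to compound 4 (0.38 log units; beyond the scatter). For compound 4 the expected value is 20000 nM, with an estimated range from 5000 nM to 80000 nM.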

Compound 4, half-maximal inhibitory concentration: 600 nM
Compound 4: the middle estimate sits 33-fold (1.52 log units) above what was measured; measured number below the stated range.
By their numbers in this assay, from the lowest: compound 4; then compound 1; then compound 2. At a limit, above all of these: compound 3.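

In this assay the step at this position is large: the exchange of 2-methoxyphenyl for 3-bromophenyl on the saturated ring carbon gives an 80-fold lower number from compound 2 to compound 4 (1.90 log units; beyond the scatter). Going by these compounds alone, this is the first change in the set that can be read at a single place, and it shows that the aryl group on this carbon, next to the ring oxygen and next to the ring atom that bears the acetyl group, has a strong bearing on the read-out, with the shared core otherwise unchanged. The entering group carries no hydrogen-bond acceptor where the leaving group carries one, yet nothing in the data accounts for the size of the step.

The step changes the kind of substituent and its place on the phenyl ring together, so the share of the lost methoxy group and the share of the bromine cannot be told apart. On these data alone, how a plain phenyl, a 3-chlorophenyl or a 3-aminophenyl would stand on this carbon remains open.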